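The compounds below may be only part of what the source reports. "The series", "measured", "known", "first", "only" and "open" are said of these compounds alone.

In a functional assay on blood (Homo sapiens) for inhibition (on this read-out higher numbers stand for weaker inhibition and lower numbers for stronger inhibition), compound 1 `CSc1nc(-c2ccc(F)cc2)c(-c2ccnc(NC(C)CCc3ccccc3)c2)[nH]1` gives 2370 nM as its reading. For compound 2 `CSc1nc(-c2ccc(F)cc2)c(-c2ccnc(NCC3CCCCC3)c2)[nH]1` the entry is "not determined" (no result reported) and so offers no number to start from. Compound 3 `CCC(Nc1cc(-c2[nH]c(SC)nc2-c2ccc(F)cc2)ccn1)c1ccccc1` differs from compound 2 by 1-phenylpropyl in place of cyclohexylmethyl on a nitrogen on an aromatic ring and carries 1-phenylpropyl in place of cyclohexylmethyl on a nitrogen on an aromatic ring. With no number for compound 2, neither the size nor the direction of this step in this assay can be stated, so the expectation rests only on compound 1 at 2370 nM as the nearest reference. Compound 3 is estimated at 1500 nM within an expected range from 350 nM to 6000 nM in that same read-out.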

Compound 3, half-maximal inhibitory concentration: 7640 nM
For compound 3 the middle estimate is 5.1-fold (0.71 log units) below the measured one; measured number outside the range, above it.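

In this assay the group on a nitrogen on an aromatic ring clearly shifts the reading: 1-phenylpropyl in place of 1-methyl-3-phenylpropyl gives a 3.2-fold higher number from compound 1 to compound 3 (0.51 log units; beyond the scatter) (weaker inhibition). Within the data shown here, this is the first measured comparison at this position, as compound 2 has no number and its step to compound 3 cannot be read. Nothing available explains the shift.

Going by these compounds, how cyclohexylmethyl compares with either group stays open, as does how a chain ending in an amine or a carboxylic acid would read at this nitrogen.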